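The source may report more compounds than this note shows. Statements on the series, on what has been measured and on what is new or still open speak of the compounds shown alone.

Compound 1 `CC(O)(CSc1ccc(S(F)(F)(F)(F)F)cc1)C(=O)Nc1ccc(C#N)cc1C(F)(F)F`: 20500 nM
Compound 2 `CC(O)(CSc1cccc(S(F)(F)(F)(F)F)c1)C(=O)Nc1ccc([N+](=O)[O-])cc1C(F)(F)F`: 28800 nM
Compound 3 `CC(O)(CSc1cccc(S(F)(F)(F)(F)F)c1)C(=O)Nc1ccc(S(F)(F)(F)(F)F)cc1`: 28200 nM

In a functional assay on VCaP cells (Homo sapiens) for antiproliferative activity, read by propidium iodide staining, with a stated time of 96 h (on this read-out higher numbers stand for weaker inhibition and lower numbers for stronger inhibition), compound 3 gives 28200 nM, which lies within the scatter of both other compounds and closest to compound 2. Compound 4 `CC(O)(CSc1cccc(C(F)(F)F)c1)C(=O)Nc1ccc(S(F)(F)(F)(F)F)cc1` carries a trifluoromethyl in place of the group of 6 heavy atoms (5 fluorine, 1 sulfur) on an aromatic carbon, meta to a large group (a group of 4 heavy atoms (1 carbon, 3 fluorine; no ring) in place of a group of 6 heavy atoms (5 fluorine, 1 sulfur; no ring), on an aromatic carbon). Going by the values given here, no measured pair shows this change alone, so the expectation rests on how closely the three values agree. No shift beyond the scatter is expected in this assay, and the estimated move is a 1.1-fold lower number from compound 3 to compound 4 (0.05 log units; within the scatter). For compound 4 the estimate is 25000 nM, with an expected range of 11000 nM to 50000 nM.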

Compound 4, half-maximal inhibitory concentration: 18800 nM
The estimate for compound 4 lay 1.3-fold (0.12 log units) above the measured number; the measured number falls inside the stated range.
By their numbers in this assay, from the lowest: compounds 4, 1, 3 and 2 (each within the scatter of the next).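

In this assay, going by these compounds alone, the first step that can be read at this position, trifluoromethyl in place of the group of 6 heavy atoms (5 fluorine, 1 sulfur), gives a 1.5-fold lower number from compound 3 to compound 4 (0.18 log units; within the scatter). On this aromatic carbon, meta to a large group, the exchange therefore leaves the number within the scatter, so the group of 6 heavy atoms is not needed to keep this level of activity. Nothing available accounts for this result.

The compounds shown leave open whether a chlorine, a methoxy or an amine on this carbon would move the number beyond the scatter. They also leave open whether the same exchange gives the same result in a compound carrying a nitrile.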